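Replacing the allylamino group of compound 3

The source may report more compounds than this note shows. Statements on the series, on what has been measured and on what is new or still open speak of the compounds shown alone.

Three related amides have been tested in a functional assay on the whole organism for antagonist activity, with Mus musculus as the target; a lower number here means that less compound is needed, a higher number that more compound is needed for the effect. Compound 1 `CCC(=O)N(c1ccccc1C)C1CCCC1N(C)C` gives 5 mg/kg, and compound 2 `CCC(=O)N(c1ccc(C)c(Cl)c1)C1CCCC1N(C)C` gives 0.6 mg/kg. Compound 3 `C=CCNC1CCCC1N(C(=O)CC)c1ccc(Cl)c(Cl)c1` gives 3 mg/kg. That puts compound 3 within the usual scatter of compound 1, so these two cannot be told apart on this evidence. Compound 2, by contrast, needs clearly less compound than compound 3, by a margin beyond the scatter.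

The untested compound 4 `CCC(=O)N(c1ccc(Cl)c(Cl)c1)C1CCCC1N(C)Cc1ccccc1` differs from compound 3 in a single place: benzyl(methyl)amino in place of allylamino on a saturated ring carbon. Among the compounds with values here, no two tested compounds differ in only one place, so no measured step shows what a swap of this kind does, and any expectation here is a cautious judgement. Compound 3 at 3 mg/kg is the closest tested relative and so serves as the starting point. The expected step in this assay is a modest rise, toward more compound being needed: a 2.7-fold higher number from compound 3 to compound 4 (0.43 log units; beyond the scatter). A fall cannot be ruled out, so the range is kept wide. For compound 4 the estimate is 8 mg/kg, with an expected range from 2 mg/kg to 30 mg/kg.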

Compound 4, dose for half-maximal effect: 40 mg/kg
Estimate against measurement, compound 4: 5.0-fold (0.70 log units) below; measured number outside the range, above it.
By their numbers in this assay, from the lowest: compound 2; then compounds 3 and 1 (each within the scatter of the next); then compound 4.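

In this assay, within the data shown here, this is the first change at a single place that can be read, and it is a large one, with a 13-fold higher number from compound 3 to compound 4 (1.12 log units; beyond the scatter) on going from allylamino to benzyl(methyl)amino. Among these compounds, the group on this saturated ring carbon therefore strongly affects how much compound is needed, which the earlier compounds could not show, as no two of them differed in only one place. The change is also several changes at once: the group gains a six-membered aromatic ring of carbon only, gives up its double bond and loses its hydrogen-bond donor, while the methyl and the benzyl arrive together on the same nitrogen.

Still open, from the compounds shown here alone, is how benzylamino, which keeps the hydrogen on nitrogen and carries the aromatic ring, or allyl(methyl)amino, which loses that hydrogen and has no ring, would compare with compound 3 and compound 4 in this assay and so separate these parts of the change. No measurement in hand explains the rise in the number between these two compounds, so its origin stays unknown.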